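Replacing the 3-hydroxy-4-methoxyphenyl group of compound 2

This account rests on a few compounds, and the source may have more. Where it says the series, first, only, none or still open, it means among the compounds named here.

In a functional assay on DU-145 cells (Homo sapiens) for inhibition, read by trypan blue exclusion, with a stated time of 96 h (a lower number here means a stronger inhibitor of growth, a higher number a weaker inhibitor of growth), compound 1 (`COc1ccc(/C=C(/SCc2ccc(Cl)cc2)C(=O)c2ccc(Br)cc2)cc1O`) gives 1000 nM and compound 2 (`COc1ccc(/C=C(/SCc2ccc(F)cc2)C(=O)c2ccc(Br)cc2)cc1O`) gives 1000 nM, so these two stand level as together the lowest of the three numbers. Compound 3 (`COc1ccc(/C=C(/SCc2ccc(F)cc2)C(=O)c2ccc(C(=O)O)cc2)cc1O`) gives 10000 nM. Fluoro in place of chloro gives no change at the digits printed from compound 1 to compound 2 (within the scatter), while carboxy in place of bromo gives a 10-fold higher number from compound 2 to compound 3 (1.00 log units; beyond the scatter).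

Compound 4 (`Cc1ccsc1/C=C(/SCc1ccc(F)cc1)C(=O)c1ccc(Br)cc1`) differs from compound 2 elsewhere, with 3-methylthiophen-2-yl in place of 3-hydroxy-4-methoxyphenyl on a double-bonded chain carbon bound to a double-bonded chain carbon. Neither measured step touches this place, so the data offer no direct guide to it. They show only how far one exchange elsewhere moved the number, as a 10-fold higher number from compound 2 to compound 3 (1.00 log units; beyond the scatter). A whole group is exchanged here, so a modestly higher number is tentatively expected, with no change beyond the scatter remaining possible. The expected step is a 3.0-fold higher number from compound 2 to compound 4 (0.48 log units; beyond the scatter). For compound 4 the estimate is 3000 nM, with an expected range of 700 nM to 12000 nM.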

Compound 4, concentration for 50% growth inhibition: 50000 nM
Estimate against measurement, compound 4: 17-fold (1.22 log units) below; measured number outside the range, above it.
By their numbers in this assay, from the lowest: compounds 1 and 2 (each within the scatter of the next); then compound 3; then compound 4.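

In this assay, among these compounds, the place on a double-bonded chain carbon bound to a double-bonded chain carbon, which no earlier step had touched, proves sensitive: 3-methylthiophen-2-yl in place of 3-hydroxy-4-methoxyphenyl gives a 50-fold higher number from compound 2 to compound 4 (1.70 log units; beyond the scatter), a large step beside the modest 10-fold higher number from compound 2 to compound 3 (1.00 log units; beyond the scatter). The exchange alters several things at once, as a six-membered aromatic ring of carbon only with 1 hydrogen-bond donor gives way to a five-membered aromatic ring with 1 hetero atom and 0 hydrogen-bond donors, so this single step cannot assign the change to any one of them. No measurement shown here accounts for the size of the step.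

Going by these compounds, how a plain phenyl, a 4-methoxyphenyl or a thiophen-2-yl without the methyl group would stand at this place remains open. Also open, on these data alone, is whether the same exchange would give a step of similar size on compound 1, which carries chloro.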